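Fluoro for bromo on the benzyl ether series

A few compounds are considered here, and "the series" means these few. Any claim that something is new, unique, unknown or untested is made for them only; others in the source may bear on it.

In a functional assay on A-375 cells (Homo sapiens) for antiproliferative activity, read by MTT assay, with a stated time of 24 h (on this read-out lower numbers stand for stronger inhibition and higher numbers for weaker inhibition), compound 1 `COc1cc(OC)c(-c2coc3cc(OCC(=O)c4cccc(C(F)(F)F)c4)ccc3c2=O)cc1OC` reaches only a limit of the assay, > 10000 nM. Going by the values given here, compound 2 `COc1cc(OC)c(-c2coc3cc(OCc4ccc(Br)cc4)ccc3c2=O)cc1OC` gives 1000 nM, the only exact number so far. Its standing can be judged against compound 1 alone. Among the compounds with values here, the one measured step, an at least 10-fold lower number from compound 1 to compound 2 (1.00 log units; beyond the scatter), put 4-bromophenyl in place of (3-(trifluoromethyl)phenyl)carbonyl, and its size is bounded by the limit of > 10000 nM in this assay, at which 1 of the 2 values shown sits.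

Compound 3 `COc1cc(OC)c(-c2coc3cc(OCc4cccc(F)c4)ccc3c2=O)cc1OC` keeps the shared core and changes one group: 3-fluorophenyl in place of 4-bromophenyl, on a saturated chain carbon bound to an oxygen on an aromatic ring (3-fluorophenyl in place of 4-bromophenyl on a saturated chain carbon bound to an oxygen on an aromatic ring). The step to compound 2, an at least 10-fold lower number from compound 1 to compound 2 (1.00 log units; beyond the scatter), removed a carbonyl as well as changing the ring substituent, so it is a poor guide to this narrower exchange. Within the data shown here, no measured step swaps one halogen-bearing phenyl for another, which leaves the direction weakly supported. A small rise in the number is expected, a 1.5-fold higher number from compound 2 to compound 3 (0.18 log units; within the scatter). Compound 3 is estimated at 1500 nM, with an expected range of 400 nM to 6000 nM.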

Compound 3, half-maximal inhibitory concentration: 1300 nM
Compound 3: middle estimate off by 1.2-fold (0.06 log units), on the high side, and the stated range covers the measured number.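

In this assay, going by these compounds alone, 3-fluorophenyl in place of 4-bromophenyl on a saturated chain carbon bound to an oxygen on an aromatic ring gives a 1.3-fold higher number from compound 2 to compound 3 (0.11 log units; within the scatter); this is the first pair with exact numbers on both sides, and at this place the two halogen-bearing phenyl groups read alike. The comparison with the carbonyl-bearing ether now rests on two benzyl ethers, with an at least 7.6-fold lower number from compound 1 to compound 3 (0.88 log units; beyond the scatter) running the same way as an at least 10-fold lower number from compound 1 to compound 2 (1.00 log units; beyond the scatter). Compound 1 remains a limit of the assay, so both of these steps are bounded and their full size is unknown: the limit of > 10000 nM in this assay, at which 1 of the 3 values shown sits.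

Compound 2 and compound 3 differ in both the halogen and its number on the ring, so neither change can be read alone, and the carbonyl of compound 1 is not separated from its trifluoromethyl group. A phenyl bearing an amine or a carboxylic acid, or a longer chain at the same place, would show whether activity at this position extends beyond halogen-bearing benzyl groups.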